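The source may hold more compounds than are shown below. What is called first, only, known or untested is meant among the compounds shown, and "the series" means these compounds.

Working notes on the series. In a functional assay on A2780 cells (Homo sapiens) for inhibition, read by sulforhodamine B assay, with a stated time of 72 h (a lower number here means a stronger inhibitor, a higher number a weaker inhibitor), compound 1 (`O=C(NCc1ccc(S(=O)(=O)N2CCCCC2)cc1)c1cnc2nccn2c1`) gives 130 nM and compound 2 (`O=C(NCc1ccc(S(=O)(=O)c2cccc(C(F)(F)F)c2)cc1)c1cc2ccncc2o1`) gives 3 nM as its value. Compound 2 therefore holds the lower of the two numbers, and the gap to compound 1 lies beyond the scatter. Among the measured compounds shown here, these two compounds differ in more than one place, so no single-change step is available yet.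

Compound 3 (`O=C(NCc1ccc(S(=O)(=O)c2cccc(C(F)(F)F)c2)cc1)c1cnc2nccn2c1`) keeps everything in compound 2 except the group on the carbonyl carbon: a group of 9 heavy atoms (6 carbon, 3 nitrogen; one five-membered aromatic ring with 2 hetero atoms, one six-membered aromatic ring with 2 hetero atoms) in place of a group of 9 heavy atoms (7 carbon, 1 nitrogen, 1 oxygen; one five-membered aromatic ring with 1 hetero atom, one six-membered aromatic ring with 1 hetero atom), on a carbonyl carbon. For the measured compounds named here, the entering group is the one already carried by compound 1, which stands at 130 nM in this assay. Compound 1 also differs from compound 3 elsewhere, so that value cannot be assigned to this group alone. A moderate weakening is expected in this assay, smaller than the whole gap between the two measured compounds and possibly not far beyond the scatter. The estimated change is a 3.3-fold higher number from compound 2 to compound 3 (0.52 log units; beyond the scatter) in the direction of a higher number. Compound 3 is expected at 10 nM (estimated range 2.5 nM to 40 nM).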

Compound 3, half-maximal inhibitory concentration: 2 nM
For compound 3 the middle estimate is 5.0-fold (0.70 log units) above the measured one; the whole stated range lies above it.
By their numbers in this assay, from the lowest: compounds 3 and 2 (each within the scatter of the next); then compound 1.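

In this assay, the exchange of groups on the carbonyl carbon gives a 1.5-fold lower number from compound 2 to compound 3 (0.18 log units; within the scatter), so this read-out does not separate the two groups at this position when the sulfonyl sulfur carries 3-(trifluoromethyl)phenyl. The large difference lies instead at the sulfonyl sulfur, where 3-(trifluoromethyl)phenyl in place of piperidin-1-yl gives a 65-fold lower number from compound 1 to compound 3 (1.81 log units; beyond the scatter), and this single-change step now ties the gap to that group with the carbonyl side held constant. No measurement available here accounts for either step.

The compounds shown leave open whether the carbonyl carbon accepts a much simpler group, such as a plain phenyl, or one carrying a carboxylic acid, and whether the silent exchange there also holds with piperidin-1-yl on the sulfonyl sulfur. They also leave open how much of the step at the sulfonyl sulfur belongs to the trifluoromethyl itself, which an unsubstituted phenyl on the sulfur would address, and whether a morpholin-4-yl would behave like piperidin-1-yl.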